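The compounds below may be only part of what the source reports. "The series", "measured", "known", "first", "only" and "open" are said of these compounds alone.

In a functional assay on cells (Burkitts lymphoma cell, Homo sapiens) for antiproliferative activity, read by MTT assay (a higher number here means a weaker inhibitor, a lower number a stronger inhibitor), compound 2 `C/C(=N\Nc1nc2ccccc2o1)c1ccccn1` gives 9 nM, the higher of the two exact numbers in this small set. Compound 1 `CC/C(=N\Nc1nc2ccccc2o1)c1ccccn1` gives 2 nM, and a 4.5-fold higher number from compound 1 to compound 2 (0.65 log units; beyond the scatter) is a modest step. Compound 3 `CC(C)(C)/C(=N\Nc1nc2ccccc2o1)c1ccccn1` reads > 10000 nM, which is a limit of the assay and not a number. Compound 4 `C/C(=N\Nc1nc2ccccc2o1)c1cnccn1` carries pyrazin-2-yl in place of pyridin-2-yl on a carbon with a double bond to nitrogen. Among the measured compounds shown here, no measured step changes this ring, so the steps at the other group on that carbon bear on it only indirectly. These are the modest 4.5-fold higher number from compound 1 to compound 2 (0.65 log units; beyond the scatter) and the large at least 1100-fold higher number from compound 2 to compound 3 (3.04 log units; beyond the scatter). Taking the modest step as the guide, a modest move towards weaker inhibition in this assay is expected. The expected step is a 3.9-fold higher number from compound 2 to compound 4 (0.59 log units; beyond the scatter). Compound 4 is estimated at 35 nM, with an expected range of 8 nM to 300 nM.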

Compound 4, half-maximal inhibitory concentration: 280 nM
For compound 4 the middle estimate is 8.0-fold (0.90 log units) below the measured one; measured number inside the range.
By their numbers in this assay, from the lowest: compound 1; then compound 2; then compound 4. At a limit, above all of these: compound 3.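

Among the compounds shown here, until this result, only the other group on this carbon had changed; compound 4 shows that the ring there also matters in this assay, with a 31-fold higher number from compound 2 to compound 4 (1.49 log units; beyond the scatter). Both rings are six-membered and aromatic, so exchanging pyridin-2-yl for pyrazin-2-yl is enough to produce a large step without any change in ring size. Nothing measured here accounts for this step.

The compounds shown leave open how a phenyl or pyrimidin-2-yl ring would read at this place. They also leave open whether pyrazin-2-yl would give a similar step with the ethyl of compound 1 on the same carbon.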